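Nitro-to-amino exchange on the shared core of compound 2

A few compounds are considered here, and "the series" means these few. Any claim that something is new, unique, unknown or untested is made for them only; others in the source may bear on it.

Compound 1 `COc1ccc(C[C@H]2C(=O)N[C@@H](C)C(=O)N(C)[C@H]3Cc4ccc(cc4)Oc4cc(cc([N+](=O)[O-])c4O)C[C@@H](C(=O)N[C@H](C)C(=O)N[C@@H](C)C(=O)N2C)N(C)C3=O)cc1` carries a free hydroxyl on the nitro-bearing aromatic ring, and in a functional assay on P388 cells (Mus musculus) for cytotoxicity (on this read-out higher numbers stand for weaker inhibition and lower numbers for stronger inhibition), compound 1 gives 0.014 ug/mL. Compound 2 `COc1ccc(C[C@H]2C(=O)N[C@@H](C)C(=O)N(C)[C@H]3Cc4ccc(cc4)Oc4cc(cc([N+](=O)[O-])c4OC)C[C@@H](C(=O)N[C@H](C)C(=O)N[C@@H](C)C(=O)N2C)N(C)C3=O)cc1` differs from it by methyl in place of hydrogen on an oxygen on an aromatic ring; in this assay compound 2 gives 0.01 ug/mL. The step of a 1.4-fold lower number from compound 1 to compound 2 (0.15 log units; within the scatter) is the only one measured so far, and it changes nothing beyond the scatter. Among the two numbers compound 2 has the lowest, but its separation from compound 1 is within the scatter, so no order between them can be claimed.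

Compound 3 `COc1ccc(C[C@H]2C(=O)N[C@@H](C)C(=O)N(C)[C@H]3Cc4ccc(cc4)Oc4cc(cc(N)c4OC)C[C@@H](C(=O)N[C@H](C)C(=O)N[C@@H](C)C(=O)N2C)N(C)C3=O)cc1` is not yet measured. It differs from compound 2 as follows: amino in place of nitro on an aromatic carbon. For the measured compounds named here, no measured step touches this aromatic carbon or replaces a nitro group, so the available data give no direct guide for this change. Going by the values given here, the one measured step, on a neighbouring oxygen, was small, which argues only weakly that the core tolerates edits at this ring. For compound 3 the expected step is a 2.0-fold higher number from compound 2 to compound 3 (0.30 log units; within the scatter), and the estimate for compound 3 in this assay is 0.02 ug/mL, with a range from 0.005 ug/mL to 0.08 ug/mL.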

Compound 3, half-maximal inhibitory concentration: 0.0071 ug/mL
The estimate for compound 3 lay 2.8-fold (0.45 log units) above the measured number; measured number inside the range.
By their numbers in this assay, from the lowest: compounds 3, 2 and 1 (each within the scatter of the next).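

In this assay, for the compounds shown here, amino in place of nitro on this aromatic carbon, ortho to a methoxy group, reads as a 1.4-fold lower number from compound 2 to compound 3 (0.15 log units; within the scatter), and this is the first measured step at the carbon itself rather than at the oxygen on the same ring. Nitro is therefore not needed on the core of compound 2 for a number in this range: nitro, with 3 heavy atoms and 0 hydrogen-bond donors, gives way to amino, with 1 heavy atom and 1 hydrogen-bond donor, and the read-out stays within the scatter. Nothing measured on these compounds offers an explanation for this result.

The compounds shown leave open whether this aromatic carbon also accepts a bulkier nitrogen group such as an acetamide or a dimethylamino group, or plain hydrogen with no substituent at all, without a step beyond the scatter. They also leave open whether amino behaves the same way alongside a free hydroxyl in place of the methoxy group, as the comparison between hydroxyl and methoxy is known only with nitro on the ring.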